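This account rests on a few compounds, and the source may have more. Where it says the series, first, only, none or still open, it means among the compounds named here.

In an ADME assay on 2209-23 cells (Homo sapiens) for cytotoxicity, read by WST assay and thymidine incorporation (on this read-out higher numbers stand for lower toxicity in this test and lower numbers for higher toxicity in this test), compound 1 (`CC(C)(C)[C@H]1C(O)=C(C2=CS(=O)(=O)c3cc(NS(C)(=O)=O)ccc3N2)C(=O)N1Cc1ccc(F)cc1`) gives > 50000 nM, which is a limit and not a number. Compound 2 (`CC(C)(C)[C@H]1C(O)=C(C2=C(Cl)S(=O)(=O)c3cc(NS(C)(=O)=O)ccc3N2)C(=O)N1Cc1ccc(F)cc1`) gives > 50000 nM, also a limit. Compound 3 (`Cc1cc(CN2C(=O)C(C3=CS(=O)(=O)c4cc(NS(C)(=O)=O)ccc4N3)=C(O)[C@@H]2C(C)(C)C)ccc1F`) gives > 50000 nM, again a limit. Compound 2 therefore has no numerical position in the series, and all three compounds stand at the limit of > 50000 nM in this assay, at which 3 of the 3 values shown sit.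

Compound 4 (`CC(C)(C)[C@H]1C(O)=C(C2=C(C#N)S(=O)(=O)c3cc(NS(C)(=O)=O)ccc3N2)C(=O)N1Cc1ccc(F)cc1`) differs from compound 2 at one place, with cyano in place of chloro on a double-bonded ring carbon, next to the ring sulfur (cyano in place of chloro on a double-bonded ring carbon). Among the compounds with values here, two measured steps bear on this change. The closer one is a step that the two limits leave unreadable from compound 1 to compound 2, with chloro in place of hydrogen on the same double-bonded ring carbon. The other is a step that the two limits leave unreadable from compound 1 to compound 3, with methyl in place of hydrogen on an aromatic carbon. Neither step has a readable size, but neither change brought a compound off the limit.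

In this assay the expected result is no shift beyond the scatter, and the estimated a number no higher from compound 2 to compound 4 (the limit leaves the size open) reflects this. Another report of a limit is the likeliest outcome. Compound 4 is expected at about 50000 nM, with an estimated range from 25000 nM to 100000 nM.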

Compound 4, half-maximal cytotoxic concentration: > 50000 nM
Compound 4: a limit, no number; the forecaster's own chance of this, stated with the estimate: 85%; the middle value sits exactly at the limit.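

In this assay compound 4 gives > 50000 nM, a limit and not a number. The steps from compound 2 and compound 1 to compound 4 cannot be read, since each joins two limits: the limit of > 50000 nM in this assay, at which 4 of the 4 values shown sit. The compounds shown leave open how far any of the four lies from that limit, and whether any change on the shared core would yield a measurable value.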